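This account rests on a few compounds, and the source may have more. Where it says the series, first, only, none or still open, it means among the compounds named here.

Going by the values given here, compound 1 `Cn1cnc2c(NC(=O)NCCN3CCC(O)(Cc4ccccc4)CC3)ccnc21` is one of only two compounds so far measured in an assay on HEK293 cells for displacement of a labelled ligand from Urotensin-2 receptor (Homo sapiens); on this read-out higher numbers stand for weaker inhibition and lower numbers for stronger inhibition. In this assay compound 1 gives 2140 nM, the higher of the two numbers; the other compound, compound 2 `CCc1cc(NC(=O)NCCN2CCC(O)(Cc3ccccc3)CC2)c2sccc2n1`, gives 60 nM, a gap well beyond the usual scatter. Compound 3 `O=C(NCCN1CCC(O)(Cc2ccccc2)CC1)Nc1ccnc2sccc12` has not been measured. It differs from compound 1 in one place: a group of 9 heavy atoms (7 carbon, 1 nitrogen, 1 sulfur; one five-membered aromatic ring with 1 hetero atom, one six-membered aromatic ring with 1 hetero atom) in place of a group of 10 heavy atoms (7 carbon, 3 nitrogen; one five-membered aromatic ring with 2 hetero atoms, one six-membered aromatic ring with 1 hetero atom), on an amide-type nitrogen. Among the compounds with values here, no measured pair shows exactly this exchange, so its size cannot be read directly from the numbers at hand. A clear move toward stronger inhibition is nevertheless expected, because in this assay compound 2 gives 60 nM while carrying a related sulfur-containing two-ring group in the same place. The expected step of a 14-fold lower number from compound 1 to compound 3 (1.15 log units; beyond the scatter) is therefore a substantial drop. Compound 3 is estimated to come in near 150 nM, with a likely range from 40 nM to 600 nM.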

Compound 3, half-maximal inhibitory concentration: 930 nM
Compound 3: middle estimate off by 6.2-fold (0.79 log units), on the low side; measured number outside the range, above it.
By their numbers in this assay, from the lowest: compound 2; then compound 3; then compound 1.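

In this assay, the exchange on the amide-type nitrogen gives a 2.3-fold lower number from compound 1 to compound 3 (0.36 log units; beyond the scatter), a modest step but one beyond the scatter. This shows that the two-ring group at this place does influence the number, and that the one with a sulfur-containing five-membered ring gives stronger inhibition than the one with a five-membered ring holding two nitrogens. Having sulfur in the group is still not enough to match the other sulfur-containing compound: compound 3 gives 930 nM, whereas compound 2 gives 60 nM.

Nothing available explains the size of this step. On these data alone, it also remains open how a chlorine atom or a methoxy group on the two-ring group of compound 3 would shift the number.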